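The compounds below may be only part of what the source reports. "The series", "measured", "known", "first", "only" and "open" are said of these compounds alone.

Among the measured compounds shown here, in a functional assay (aorta) with Rattus norvegicus as the target (a higher number here means that more compound is needed for the effect, a lower number that less compound is needed), two compounds with a shared core have numbers so far. Compound 1 `COc1ccc(-c2nc(N=C(N)N)sc2-c2ccc(OC)cc2)cc1` gives 2 uM, while compound 2 `COc1ccc(-c2nc(/N=C(\N)N3CCOCC3)sc2-c2ccc(OC)cc2)cc1` gives 66 uM, the higher of the two numbers. More of compound 2 is therefore needed for the effect.

Compound 3 `COc1ccc(-c2nc(CNC(C)=O)sc2-c2ccc(OC)cc2)cc1` has not yet been measured. It keeps the shared core with its two 4-methoxyphenyl groups, and its difference from compound 2 is a group of 5 heavy atoms (3 carbon, 1 nitrogen, 1 oxygen; no ring) in place of a group of 9 heavy atoms (5 carbon, 3 nitrogen, 1 oxygen; one six-membered non-aromatic ring with 2 hetero atoms), on an aromatic carbon. The new acetamidomethyl group has no ring, unlike the group it replaces.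

For the measured compounds named here, the only measured step that bears on this change is a 33-fold higher number from compound 1 to compound 2 (1.52 log units; beyond the scatter), a large step beyond the scatter, where a ringed group took the place of a smaller group without a ring. Removing the ring might recover part of that step. The acetamidomethyl group is not the group of compound 1, however, and a single step gives only loose guidance, so a full return is not expected. A moderate fall in this assay is expected, with an estimated size of a 2.6-fold lower number from compound 2 to compound 3 (0.42 log units; beyond the scatter). For compound 3 the estimated value is 25 uM, with an expected range from 5 uM to 100 uM.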

Compound 3, concentration for half-maximal effect: 8.1 uM
Compound 3: middle estimate off by 3.1-fold (0.49 log units), on the high side, within the range that was stated.
By their numbers in this assay, from the lowest: compound 1; then compound 3; then compound 2.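

At this aromatic carbon, in this assay, putting acetamidomethyl in place of the ringed group gives an 8.1-fold lower number from compound 2 to compound 3 (0.91 log units; beyond the scatter), so the high number of compound 2 belongs to its group and not to the shared core alone. The same change also shows that a group quite unlike that of compound 1 can still bring much of the number back down, although the gap is not closed: a 4.1-fold higher number from compound 1 to compound 3 (0.61 log units; beyond the scatter), and this step also lies beyond the usual scatter, which leaves compound 1 with the lowest number of the three. No supporting measurement is available to explain either step.

From the compounds shown here alone, what remains open is which difference between the groups matters, since acetamidomethyl differs from the group in compound 2 in more than the loss of the ring, and three compounds cannot separate ring, size and atom makeup. A plain aminomethyl group, a carboxylic acid or a longer chain ending in the same amide on this carbon would help show whether the number can fall further or rises again.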